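This account rests on a few compounds, and the source may have more. Where it says the series, first, only, none or still open, it means among the compounds named here.

Compound 1 `O=C(Nc1cccc(CNc2nccnc2Cl)c1)NC1CCCC1` gives 18400 nM in a functional assay on HepG2 cells (Homo sapiens) for antiproliferative activity, read by MTT assay, with a stated time of 48 h; a lower number here means a stronger inhibitor, a higher number a weaker inhibitor. Compound 2 `O=C(Nc1cccc(CNc2nccnc2Cl)c1)Nc1ccc(F)c(Cl)c1` gives 6750 nM in this assay, a change of a 2.7-fold lower number from compound 1 to compound 2 (0.44 log units; beyond the scatter). On the numbers shown, compound 2 stands lowest of the two, with compound 1 as its only neighbour. Compound 3 `CCc1ccccc1NC(=O)Nc1cccc(CNc2nccnc2Cl)c1` has not yet been measured; it differs from compound 2 in one place: 2-ethylphenyl in place of 3-chloro-4-fluorophenyl on an amide-type nitrogen. Among the measured compounds shown here, the single measured step bears on this only loosely, since it also sits on that nitrogen, but there cyclopentyl gave way to 3-chloro-4-fluorophenyl, whereas here one six-membered aromatic ring of carbon only replaces another of the same size. For compound 3 the expected step is therefore a 1.2-fold higher number from compound 2 to compound 3 (0.07 log units; within the scatter), a move that is not expected to exceed the scatter in either direction. For compound 3 the estimate in this assay is 8000 nM, with a range from 3000 nM to 25000 nM.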

Compound 3, half-maximal inhibitory concentration: 7860 nM
Compound 3: the middle estimate sits 1.0-fold (0.01 log units) above what was measured; low and high end bracket the measured number.
By their numbers in this assay, from the lowest: compounds 2 and 3 (each within the scatter of the next); then compound 1.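

In this assay, the change on the amide-type nitrogen from 3-chloro-4-fluorophenyl to 2-ethylphenyl gives a 1.2-fold higher number from compound 2 to compound 3 (0.07 log units; within the scatter) and so separates these two substituted rings no more than repeat measurements would, although one carries chlorine and fluorine and the other only carbon. Set against cyclopentyl, 2-ethylphenyl gives a 2.3-fold lower number from compound 1 to compound 3 (0.37 log units; beyond the scatter) and thereby shows that, among these three compounds, the modest step first seen with 3-chloro-4-fluorophenyl also appears with a second aromatic group, and none of the three goes against this. Nothing measured here explains either result.

As far as these compounds go, it remains open whether an unsubstituted phenyl ring would fall in the same range as compound 2 and compound 3. Equally open, from the compounds shown here alone, is how a pyridine ring, or a phenyl ring carrying an amine or a carboxylic acid, would fare at this nitrogen.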